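Chloro placement on the anilide end of the chain

The source may hold more compounds than are shown below. What is called first, only, known or untested is meant among the compounds shown, and "the series" means these compounds.

Measured so far:
- compound 1, `Cn1c(Cc2nn(C)c(=O)c3ccccc23)nnc1SCCCCCCCCCC(=O)Nc1ccc(Cl)cc1Cl`: 2300 nM
- compound 2, `Cn1c(Cc2nn(C)c(=O)c3ccccc23)nnc1SCCCCCCCCCCC(=O)Nc1ccc(Cl)cc1Cl`: 3300 nM
- compound 3, `Cn1c(Cc2nn(C)c(=O)c3ccccc23)nnc1SCCCCCCCCCCC(=O)Nc1ccccc1Cl`: 15000 nM

All three share the same core and the long sulfur-linked chain ending in an anilide; they differ only at the chain end and in the chlorination of the aryl ring. In an assay on isolated protein (Mus musculus) for inhibition of IL15-IL15 receptor (Homo sapiens), read by resazurin assay, with stated times of 30 min and 2.5 days (a lower number here means a stronger inhibitor, a higher number a weaker inhibitor), compound 3 gives the highest number of the three: a 6.5-fold higher number from compound 1 to compound 3 (0.81 log units; beyond the scatter) and a 4.5-fold higher number from compound 2 to compound 3 (0.66 log units; beyond the scatter), both beyond the scatter, while a 1.4-fold higher number from compound 1 to compound 2 (0.16 log units; within the scatter) is within it.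

Compound 4, `Cn1c(Cc2nn(C)c(=O)c3ccccc23)nnc1SCCCCCCCCCCC(=O)Nc1ccc(Cl)cc1`, has not been measured. Relative to compound 3 the change is 4-chlorophenyl in place of 2-chlorophenyl on an amide-type nitrogen. For the measured compounds named here, no measured step covers this exact rearrangement. The one that bears on it is the removal of a chloro in a 4.5-fold higher number from compound 2 to compound 3 (0.66 log units; beyond the scatter), which shows that the aryl chlorination pattern matters at a modest size. Compound 4 retains a chloro at the position whose loss hurt there, so a modestly lower number than compound 3 is expected, a 2.5-fold lower number from compound 3 to compound 4 (0.40 log units; beyond the scatter), though the direction is uncertain. The estimate for compound 4 in this assay is 6000 nM (range 2500 nM to 20000 nM).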

Compound 4, half-maximal inhibitory concentration: 20000 nM
Beside the measured number, compound 4's estimate is 3.3-fold (0.52 log units) below it; the range from low to high includes it.
By their numbers in this assay, from the lowest: compounds 1 and 2 (each within the scatter of the next); then compounds 3 and 4 (each within the scatter of the next).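

In this assay, the single chloro gives no separation between 2-chlorophenyl and 4-chlorophenyl on the amide-type nitrogen (a 1.3-fold higher number from compound 3 to compound 4 (0.12 log units; within the scatter)), so among these compounds the placement of one chloro does not register. Either monochloro anilide sits beyond the scatter from the dichloro anilide of the same chain length, whichever chloro remains (a 6.1-fold higher number from compound 2 to compound 4 (0.78 log units; beyond the scatter); a 4.5-fold higher number from compound 2 to compound 3 (0.66 log units; beyond the scatter)), and the step that also changes the chain end is of similar size (an 8.7-fold higher number from compound 1 to compound 4 (0.94 log units; beyond the scatter)). In these four compounds, the lower numbers go with two chloro groups rather than with the placement of one, and no supporting data are available to explain this.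

From the compounds shown here alone, what a plain phenyl anilide would give remains open, as does the effect of a methoxy or trifluoromethyl group in place of chloro. Whether the monochloro anilides tolerate a shorter chain as the dichloro pair does is also unresolved.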